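Ring-Closing the Acid Chain: What to Expect of Compound 4

This account rests on a few compounds, and the source may have more. Where it says the series, first, only, none or still open, it means among the compounds named here.

Compound 3 `C[C@H](NC(=O)c1cc(F)cc2cc(-c3ccc(Cl)cc3)oc12)C(=O)O` gives 4440 nM in an assay on isolated protein for inhibition of endoplasmic reticulum aminopeptidase 1 (Homo sapiens), with stated times of 15 min and 20 min (on this read-out higher numbers stand for weaker inhibition and lower numbers for stronger inhibition), the highest of the two numbers measured there. Its nearest neighbour, compound 2 `CC(C)(NC(=O)c1cc(F)cc2cc(-c3ccc(Cl)cc3)oc12)c1nnn[nH]1`, gives 275 nM in this assay, and the gap between them is a 16-fold higher number from compound 2 to compound 3 (1.21 log units; beyond the scatter). Compound 1 `CC(C)(NC(=O)c1cc(F)cc2cc(-c3ccc(Cl)cc3)oc12)C(N)=O` reaches only the limit of > 10000 nM in this assay (the limit of > 10000 nM in this assay, at which 1 of the 3 values shown sits). From compound 1 to compound 3 the step was an at least 2.2-fold lower number from compound 1 to compound 3 (0.35 log units; beyond the scatter), and from compound 1 to compound 2 it was an at least 36-fold lower number from compound 1 to compound 2 (1.56 log units; beyond the scatter). Compound 4 `O=C(NC1(C(=O)O)CC1)c1cc(F)cc2cc(-c3ccc(Cl)cc3)oc12` differs from compound 3 by 1-carboxycyclopropyl in place of 1-carboxyethyl on an amide-type nitrogen. Going by the values given here, since the carboxylic acid of compound 3 is retained and no measured step separates a cyclopropyl from an open chain, no step beyond the scatter is expected. Compound 4 is therefore expected to give about 3500 nM in this assay, between 900 nM and 12000 nM, which would be a step of a 1.3-fold lower number from compound 3 to compound 4 (0.10 log units; within the scatter).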

Compound 4, half-maximal inhibitory concentration: 1120 nM
For compound 4 the middle estimate is 3.1-fold (0.49 log units) above the measured one, within the range that was stated.
By their numbers in this assay, from the lowest: compound 2; then compound 4; then compound 3. At a limit, above all of these: compound 1.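

In this assay, a 4.0-fold lower number from compound 3 to compound 4 (0.60 log units; beyond the scatter), so the carbon framework carrying the carboxylic acid on this amide-type nitrogen, and not only the acid itself, shifts the number. Even so, the tetrazole keeps its lead, with a 4.1-fold higher number from compound 2 to compound 4 (0.61 log units; beyond the scatter). Against the primary amide the step is an at least 8.9-fold lower number from compound 1 to compound 4 (0.95 log units; beyond the scatter), and it has no fixed size, since compound 1 stands at a limit: the limit of > 10000 nM in this assay, at which 1 of the 4 values shown sits.

From the compounds shown here alone, what an open-chain 1-carboxy-1-methylethyl group would give stays open, and with it whether the ring or the added carbon carries the step. Also open, going by these compounds, is how 1-(1H-tetrazol-5-yl)cyclopropyl or 1-carboxycyclobutyl would compare.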